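The compounds below may be only part of what the source reports. "The series", "measured", "known", "first", "only" and "open" are said of these compounds alone.

The shared core carries a ring system on one side and, on the other, a five-membered non-aromatic ring with one nitrogen and one oxygen; the compounds differ only in the group attached to that saturated ring. In a physicochemical assay for lipophilicity, read by HPLC, measured as octanol-water partition (on this read-out higher numbers stand for higher lipophilicity and lower numbers for lower lipophilicity), compound 1 `O=C1O[C@@H](CN2CCCCC2)CN1c1ccc(-n2cc(-c3ccccn3)cn2)c(F)c1` gives 3.1, compound 2 `O=C1CNC(=O)N1C[C@H]1CN(c2ccc(-n3cc(-c4ccccn4)cn3)c(F)c2)C(=O)O1` gives 1.25 and compound 3 `O=C1O[C@@H](Cn2ccnc2)CN1c1ccc(-n2cc(-c3ccccn3)cn2)c(F)c1` gives 1.73. Among these three numbers compound 3 stands second highest: its nearest neighbour is compound 2, which sits lower, while compound 1 sits furthest away and higher.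

Compound 4 `NC(=O)[C@H]1CN(c2ccc(-n3cc(-c4ccccn4)cn3)c(F)c2)C(=O)O1` is the next variant, and it differs from compound 3 by carbamoyl in place of (1H-imidazol-1-yl)methyl on a saturated ring carbon. Among the compounds with values here, two measured steps bear on this change. Both alter the same position. Exchanging piperidin-1-yl for 1H-imidazol-1-yl gave a number 1.37 log units lower from compound 1 to compound 3 (beyond the scatter), and exchanging 2,5-dioxoimidazolidin-1-yl for 1H-imidazol-1-yl gave a number 0.48 log units higher from compound 2 to compound 3 (beyond the scatter). The carbamoyl group, with its one hydrogen-bond donor and one acceptor, resembles the hydantoin of compound 2 more than the imidazole of compound 3, so a step downward in this assay is expected, modest rather than large.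

Compound 4 is therefore estimated at 1.2, within a range from 0.6 to 1.8, which corresponds to an expected step of a number 0.53 log units lower from compound 3 to compound 4 (beyond the scatter).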

Compound 4, partition coefficient: 1.59
For compound 4 the middle estimate is 0.39 log units below the measured one; the measured number falls inside the stated range.
By their numbers in this assay, from the lowest: compound 2; then compounds 4 and 3 (each within the scatter of the next); then compound 1.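

In this assay, a number 0.14 log units lower from compound 3 to compound 4 (within the scatter) follows the replacement of (1H-imidazol-1-yl)methyl by carbamoyl, even though the entering group has 3 heavy atoms rather than 6, no ring and a hydrogen-bond donor. The earlier compounds shown here changed only what hung from a saturated chain carbon, whereas compound 4 has no such chain carbon and carries its group directly on the saturated ring carbon next to the ring oxygen, so this position tolerates a much shorter, ring-free group with no resolved shift from the imidazole compound. The same change gives a number 0.34 log units higher from compound 2 to compound 4 (beyond the scatter) and a number 1.51 log units lower from compound 1 to compound 4 (beyond the scatter) as well, so compound 4 stays clearly apart from both and the size of the step depends on which group leaves.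

No measurement shown here explains these numbers. As far as these compounds go, it also remains open whether a carboxylic acid or a primary amine on this ring carbon, or a carbamoyl group set on a longer chain, would stay in the range of compound 3 and compound 4 or move towards compound 1.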